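The source may hold more compounds than are shown below. What is called first, only, known or untested is meant among the compounds shown, and "the series" means these compounds.

In an ADME assay on microsomes from liver (Homo sapiens) for metabolic stability (on this read-out higher numbers stand for fast clearance and lower numbers for slow clearance), three compounds with a shared core have been measured. Compound 1 `CCn1cnc2c(-c3ccc(F)c(OCc4ccccn4)c3)cnnc21` gives 41 mL.min-1.g-1.

Compound 2 `CCn1cnc2c(-c3ccc(F)c(-c4ccc(S(=O)(=O)CC)cc4)c3)cnnc21` is reported only as a limit, < 13 mL.min-1.g-1, and not as a number.

Compound 3 `CCOc1cc(S(=O)(=O)CC)ccc1-c1cc(-c2cnnc3c2ncn3CC)ccc1F` gives 12 mL.min-1.g-1, the lower of the two actual numbers, and the gap up to compound 1 lies beyond the usual scatter. Compound 3 therefore stands at the slow-clearance end of this small set.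

Compound 4 `CCn1cnc2c(-c3ccc(F)c(-c4ccc(S(=O)(=O)CC)cc4Cl)c3)cnnc21` differs from compound 3 in one place, with chloro in place of ethoxy on an aromatic carbon, ortho to a large group and meta to an ethylsulfonyl group: chloro in place of ethoxy on an aromatic carbon.

Going by the values given here, the one measured step that touches this position is a step that the limit leaves unreadable from compound 2 to compound 3, where ethoxy replaces hydrogen. That step gives neither a size nor a direction, so it offers no measured effect to carry over to chloro. The expectation rests instead on compound 3 at 12 mL.min-1.g-1, and no shift beyond the scatter is expected in this assay. The expected change is a 1.2-fold higher number from compound 3 to compound 4 (0.07 log units; within the scatter).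

For compound 4, the estimated value is 14 mL.min-1.g-1, with an expected range of 7 mL.min-1.g-1 to 28 mL.min-1.g-1.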

Compound 4, intrinsic clearance in microsomes: 9 mL.min-1.g-1
Estimate against measurement, compound 4: 1.6-fold (0.19 log units) above, and the stated range covers the measured number.
By their numbers in this assay, from the lowest: compounds 4 and 3 (each within the scatter of the next); then compound 1.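

In this assay, going by these compounds alone, putting chloro in place of ethoxy on this aromatic carbon, ortho to a large group and meta to an ethylsulfonyl group, gives a 1.3-fold lower number from compound 3 to compound 4 (0.12 log units; within the scatter), the first step at this position that can be read as a number. Ethoxy brings 3 heavy atoms and 1 hydrogen-bond acceptor, while chloro brings 1 heavy atom and no acceptor, yet this read-out does not separate the two compounds, so in this pair the position accepts either group without a measurable change in clearance. The steps from compound 2, which has hydrogen at this place, to compound 3 and to compound 4 cannot be read because compound 2 is reported only as a limit: the limit of < 13 mL.min-1.g-1 in this assay, at which 1 of the 4 values shown sits.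

On these data alone, it therefore stays open whether ethoxy or chloro changes clearance at all compared with hydrogen at this position. As far as these compounds go, it also stays open whether an amine, a carboxylic acid or a longer chain such as butoxy on the same carbon would give a number in the same range as compound 3 and compound 4.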